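Moving the Chloro Group: An Expected Flat Step

The source may hold more compounds than are shown below. What is called first, only, known or untested is meant among the compounds shown, and "the series" means these compounds.

compound 1 `COc1cc(OC)c(OC)cc1/C=C/COC(=O)/C=C/c1ccc(Br)cc1` 100%
compound 2 `COc1cc(OC)c(OC)cc1/C=C/COC(=O)/C=C/c1ccccc1C(F)(F)F` 100%
compound 3 `COc1cc(OC)c(OC)cc1/C=C/COC(=O)/C=C/c1ccccc1Cl` 100%

All three compounds were tested in a functional assay on the whole organism (strain Kunming) with Mus musculus as the target, with a stated time of 0.5 h, at a dose of 100 mg/kg by the intraperitoneal route; a lower number here means a stronger effect, a higher number a weaker effect of the compound at the dose given. Compound 3 stands level with compound 1 and compound 2 in this assay. Every measured step is flat: no change at the digits printed from compound 1 to compound 2 (within the scatter), no change at the digits printed from compound 1 to compound 3 (within the scatter) and no change at the digits printed from compound 2 to compound 3 (within the scatter). Compound 4 `COc1cc(OC)c(OC)cc1/C=C/COC(=O)/C=C/c1ccc(Cl)cc1` differs from compound 3 by 4-chlorophenyl in place of 2-chlorophenyl on a double-bonded chain carbon bound to a double-bonded chain carbon. Among the compounds with values here, no measured step moves a chloro group around the ring in this way, but the three aryl variants already seen, among them compound 1 with its 4-bromophenyl, all read alike, so no change beyond the scatter is expected. Compound 4 is therefore estimated at 100%, with a range from 85% to 100%. The expected step is no change at the digits printed from compound 3 to compound 4 (within the scatter).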

Compound 4, a percentage reported as activity, at one dose (the size of the read-out at that dose, not a potency): 100%
Compound 4: the middle estimate sits on the measured number at the digits printed; the range from low to high includes it.
By their numbers in this assay, from the lowest: compounds 1, 2, 3 and 4 (each within the scatter of the next).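

Shifting the chloro group from 2-chlorophenyl to 4-chlorophenyl gives no change at the digits printed from compound 3 to compound 4 (within the scatter) in this assay and is the first measured move of one substituent around this ring, so for this pair the chloro group's place does not register. Chloro in place of bromo gives no change at the digits printed from compound 1 to compound 4 (within the scatter) as the first direct exchange of one halogen for another, and 4-chlorophenyl in place of 2-(trifluoromethyl)phenyl gives no change at the digits printed from compound 2 to compound 4 (within the scatter) as well. No supporting measurement explains these flat steps.

Going by these compounds, whether an amine or a carboxylic acid on this ring would shift the read-out remains open. So does the effect of a longer chain at this place.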